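This account rests on a few compounds, and the source may have more. Where it says the series, first, only, none or still open, it means among the compounds named here.

Measured compounds:
compound 1, `Cc1cc(NC(=O)Cn2nnc(-c3ccc(F)c(F)c3)n2)n(C2CCCCC2)n1`: 93%
compound 2, `Cc1cc(NC(=O)Cn2nnc(-c3ccnc(F)c3)n2)n(C2CCCCC2)n1`: 95%

Both numbers come from an assay on HEK293 cells for activation of Kir3.1/Kir3.2 (Homo sapiens), read by thallium flux; a lower number here means a smaller maximal response, a higher number a larger maximal response. Within the data shown here, compound 2 and compound 1 lie within the scatter of each other, so the two show the same full response; the only measured step, a number 2 percentage points higher from compound 1 to compound 2 (within the scatter), stays within the scatter and concerns the same aromatic ring that changes now. Compound 3, `COc1ccc(-c2nnn(CC(=O)Nc3cc(C)nn3C3CCCCC3)n2)cc1`, is not yet measured. It differs from compound 2 thus: 4-methoxyphenyl in place of 2-fluoropyridin-4-yl on an aromatic carbon. Among the measured compounds shown here, with the one comparable step flat, no movement beyond the scatter is expected in this assay , and the estimated step is a number 3 percentage points lower from compound 2 to compound 3 (within the scatter). Compound 3 is expected to give 92%, in the range 78% to 104%.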

Compound 3, largest response reached (Emax), in percent of the reference or control that the assay uses: 90%
Compound 3: the middle estimate sits 2 percentage points above what was measured, within the range that was stated.
By their numbers in this assay, from the lowest: compounds 3, 1 and 2 (each within the scatter of the next).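

In this assay, 4-methoxyphenyl brings an oxygen-bearing group with a carbon-only ring to this position, and the response stays flat: a number 5 percentage points lower from compound 2 to compound 3 (within the scatter) and a number 3 percentage points lower from compound 1 to compound 3 (within the scatter). Across the three compounds shown, the full response therefore requires neither fluorine nor a ring nitrogen in the group at this position. No measured information accounts for this flatness.
Going by these compounds, whether an amine or a carboxylic acid on the aromatic ring would move the response beyond the scatter remains open. So does the effect of replacing that aromatic ring with a saturated ring such as piperidine.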